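Removing chloro on two different arms of one series

The source may report more compounds than this note shows. Statements on the series, on what has been measured and on what is new or still open speak of the compounds shown alone.

Compound 1 `COc1ccc(CNC(=O)CSc2nc3ccc(NC(=O)c4ccc(Cl)cc4)cc3s2)cc1` and compound 2 `COc1ccc(CNC(=O)CSc2nc3ccc(NC(=O)c4ccccc4)cc3s2)cc1` share a core and differ in a single place, (hydrogen in place of chloro on an aromatic carbon), the change falling on the benzoyl arm. In a functional assay on MCF7 cells (Homo sapiens) for cytotoxicity, read by MTT assay, with a stated time of 48 h (a lower number here means a stronger inhibitor, a higher number a weaker inhibitor), compound 1 gives 19200 nM. In this assay compound 2 gives 21200 nM. The step of a 1.1-fold higher number from compound 1 to compound 2 (0.04 log units; within the scatter).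

Compound 3 `O=C(CSc1nc2ccc(NC(=O)c3ccc([N+](=O)[O-])cc3)cc2s1)NCc1ccc(Cl)cc1` carries a different core; the difference between the two cores is not broken down here. In this assay compound 3 gives only a limit, > 100000 nM. That value sits at the limit of > 100000 nM in this assay, at which 1 of the 3 values shown sits.

Compound 4 `O=C(CSc1nc2ccc(NC(=O)c3ccc([N+](=O)[O-])cc3)cc2s1)NCc1ccccc1` has not yet been measured in this assay. It differs from compound 3 by hydrogen in place of chloro on an aromatic carbon, here on the benzyl arm rather than the benzoyl arm, but the same change at the same kind of place.

The step is expected to be a step that the limit leaves unreadable from compound 3 to compound 4, an expectation that rests on a 1.1-fold higher number from compound 1 to compound 2 (0.04 log units; within the scatter). Compound 4 is therefore estimated to give about 150000 nM in this assay, between 50000 nM and 450000 nM, most likely reported again as a limit.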

Compound 4, half-maximal inhibitory concentration: > 100000 nM
Compound 4 ended at the assay's limit (the forecaster's own chance of this, stated with the estimate: 70%); the middle value is on the limit's open side.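

Compound 3 and compound 4 both end at a limit rather than at a number, so no step between them can be read in this assay: the limit of > 100000 nM in this assay, at which 2 of the 4 values shown sit.

The compounds shown leave open whether going from 4-chlorobenzyl to benzyl has any effect at all, as neither compound 3 nor compound 4 has a number to compare.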